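Dichloropurine step in a fused-core cytotoxicity series

The source may hold more compounds than are shown below. What is called first, only, known or untested is meant among the compounds shown, and "the series" means these compounds.

Measured so far:
Compound 1 `ClCc1ccccc1Cn1cnc2c(Cl)ncnc21` — in a functional assay on TK-10 cells (Homo sapiens) for cytotoxicity, read by sulforhodamine B assay, with a stated time of 48 h (on this read-out lower numbers stand for stronger inhibition of growth and higher numbers for weaker inhibition of growth), compound 1 gives 46800 nM.
Compound 2 `ClCc1ccccc1Cn1cnc2ncnc(Cl)c21` — in this assay compound 2 gives 9540 nM.

Compound 2 holds the lowest of the two numbers; the nearest is compound 1, whose number is higher by a gap beyond the scatter. Among the measured compounds shown here, no single-point step between measured compounds is available, so the series gives no calibration for a further halogen on the core.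

Compound 3 `ClCc1ccccc1Cn1cnc2nc(Cl)nc(Cl)c21` is the next entry, not yet measured. It differs from compound 2 by chloro in place of hydrogen on an aromatic carbon, on the carbon between two ring nitrogen atoms, meta to the existing chloro group. For the measured compounds named here, with no measured analogue for this change, the expected step of a 1.6-fold lower number from compound 2 to compound 3 (0.20 log units; within the scatter) is small, possibly toward a lower number but not clearly beyond the scatter. The estimate for compound 3 is 6000 nM, with a range from 2000 nM to 20000 nM.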

Compound 3, concentration for total growth inhibition: 33900 nM
The estimate for compound 3 lay 5.7-fold (0.75 log units) below the measured number, and the stated range ends below it.
By their numbers in this assay, from the lowest: compound 2; then compounds 3 and 1 (each within the scatter of the next).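

In this assay the chloro group entering on the aromatic carbon between two ring nitrogen atoms gives a 3.6-fold higher number from compound 2 to compound 3 (0.55 log units; beyond the scatter) and so supplies the only calibration for a further halogen on the shared core. The step is modest but points toward weaker inhibition of growth, so this carbon is not indifferent to substitution: a single added heavy atom moves the read-out beyond the scatter. Nothing measured here accounts for the step.

As far as these compounds go, whether the step is specific to chloro or follows any replacement of hydrogen on this carbon stays open, and a fluoro group, a methoxy group or an amine at the same place would separate those readings. Also open, from the compounds shown here alone, is whether the same change carries over to the core of compound 1 with a comparable step.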